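This account rests on a few compounds, and the source may have more. Where it says the series, first, only, none or still open, it means among the compounds named here.

The measured compounds:
Compound 1 `Nc1nc(NCc2cccs2)nc2sc(-c3ccco3)nc12` gives 75 nM in a functional assay on CHO cells for agonist activity at adenosine receptor A2b (Homo sapiens), read by scintillation counting and cAMP accumulation, with a stated time of 150 min, in the presence of a further agent that is not named here; a higher number here means a weaker inhibitor, a lower number a stronger inhibitor.
Compound 2 `Nc1nc(NCc2cccs2)nc2sc(-c3cccs3)nc12` gives 547 nM in this assay.
Compound 3 `Cc1ccc(-c2nc3c(N)nc(NCc4cccs4)nc3s2)o1` gives 91 nM in this assay.

Compound 1 has the lowest number of the three. Compound 3 sits nearest, at a 1.2-fold higher number from compound 1 to compound 3 (0.08 log units; within the scatter), a gap within the scatter, so no order can be drawn between these two; compound 2 lies furthest, at a 7.3-fold higher number from compound 1 to compound 2 (0.86 log units; beyond the scatter), and the step of a 6.0-fold lower number from compound 2 to compound 3 (0.78 log units; beyond the scatter) runs back the other way.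

Compound 4 `Nc1nc(NCc2ccncc2)nc2sc(-c3ccco3)nc12` differs from compound 1 in one place: pyridin-4-yl in place of thiophen-2-yl on a saturated chain carbon bound to a nitrogen on an aromatic ring. Every measured step changes the group on the aromatic carbon of the shared core; none touches the saturated chain carbon bound to the ring nitrogen. The modest steps of a 7.3-fold higher number from compound 1 to compound 2 (0.86 log units; beyond the scatter) and a 6.0-fold lower number from compound 2 to compound 3 (0.78 log units; beyond the scatter) show that exchanging one small aromatic ring for another can shift the number beyond the scatter in this series, but they say nothing about this position. Going by the values given here, no measured step bears directly on the change, so the expectation rests only on the size of swings seen elsewhere in the set: a shift within or modestly beyond the scatter, with no direction favoured. Compound 4 is expected to give 150 nM, in the range 40 nM to 600 nM, which as a step means an expected 2.0-fold higher number from compound 1 to compound 4 (0.30 log units; within the scatter).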

Compound 4, half-maximal inhibitory concentration: 33 nM
Compound 4: the middle estimate sits 4.5-fold (0.66 log units) above what was measured; the whole stated range lies above it.
By their numbers in this assay, from the lowest: compound 4; then compounds 1 and 3 (each within the scatter of the next); then compound 2.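

In this assay, going by these compounds alone, the exchange of thiophen-2-yl for pyridin-4-yl on a saturated chain carbon bound to a nitrogen on an aromatic ring brings a 2.3-fold lower number from compound 1 to compound 4 (0.36 log units; beyond the scatter) and so gives the first sign that this position, untouched by the earlier steps, can also move the number beyond the scatter. The step is modest, but it shows that a six-membered aromatic ring with one hetero atom can stand here in place of a five-membered one without any loss in this read-out, with the furan-2-yl group held constant on the shared core. Nothing available explains the lower number.

The compounds shown offer only this single exchange at this position, so it remains open whether the same exchange would carry over to compound 2 or compound 3, where the group on the aromatic carbon differs. On these data alone, it is also open how phenyl, pyridin-3-yl, or a longer chain carrying the pyridin-4-yl group would behave in place of the (pyridin-4-yl)methyl group.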